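Methoxy in place of trifluoromethoxy, with no readable anchor

The source may hold more compounds than are shown below. What is called first, only, known or untested is meant among the compounds shown, and "the series" means these compounds.

Measured compounds:
Compound 1, `COc1ccc(-n2c(=O)n(Cc3cc4cc(Cl)ccc4n3CCCC#N)c3cnccc32)cc1C`: in an ADME assay on HeLa cells (Homo sapiens) for cytotoxicity, read by ATP content, with a stated time of 3 days (a lower number here means that less compound is tolerated, a higher number that more compound is tolerated), compound 1 gives > 50000 nM, which is a limit of the assay and not a number.
Compound 2, `N#CCCCn1c(Cn2c(=O)n(-c3ccc(OC(F)(F)F)cc3)c3ccncc32)cc2cc(Cl)ccc21`: in this assay compound 2 gives > 50000 nM, likewise a limit of the assay.

Going by the values given here, compound 2 therefore stands only at a limit, and the one further value shown, that of compound 1, is a limit as well; both values sit at the limit of > 50000 nM in this assay, at which 2 of the 2 values shown sit. Among the compounds with values here, the single measured step, a step that the two limits leave unreadable from compound 1 to compound 2, exchanges groups on the same aromatic nitrogen that the new change touches, but with both of its ends at the limit it has no readable size or direction.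

Compound 3, `COc1ccc(-n2c(=O)n(Cc3cc4cc(Cl)ccc4n3CCCC#N)c3cnccc32)cc1`, differs from compound 2 by methyl in place of trifluoromethyl on an oxygen on an aromatic ring. Within the data shown here, the only measured step that bears on this part of the molecule is unreadable, so no size of step in this assay can be derived from it, in either direction, and nothing beyond the scatter is expected. Compound 3 is estimated to show 50000 nM, within 20000 nM to 120000 nM. The step of a number no higher from compound 2 to compound 3 (the limit leaves the size open) is expected to stay within the scatter, with the result most likely reported again as a limit.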

Compound 3, half-maximal cytotoxic concentration: > 50000 nM
Compound 3: a limit, no number; the forecaster's own chance of this, stated with the estimate: 80%; the middle value lies on the limit itself.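

Going by these compounds alone, compound 1, compound 2 and compound 3 all stand at a limit of this assay, so no step among them can be read, and all three sit together: the limit of > 50000 nM in this assay, at which 3 of the 3 values shown sit. The compounds shown leave open at what concentration any of them would become cytotoxic, and whether exchanging 4-methoxyphenyl, 4-methoxy-3-methylphenyl or 4-(trifluoromethoxy)phenyl changes that concentration at all.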